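The compounds below may be only part of what the source reports. "The series", "measured", "known", "first", "only" and "open" are said of these compounds alone.

Measured so far:
- compound 1 `CCCc1ccc(C(=O)Nc2ccccc2-c2nnn(-c3cccc(OC)c3)n2)cc1` gives 121 nM
- compound 2 `COc1cccc(-n2nnc(-c3ccccc3NC(=O)c3ccc(N=[N+]=[N-])cc3)n2)c1` gives 415 nM
- compound 3 `COc1cccc(-n2nnc(-c3ccccc3NC(=O)c3ccc(NC(=O)CBr)cc3)n2)c1` gives 250 nM

In a functional assay on NCI-H460 cells (Homo sapiens) for positive allosteric modulation, read by MTT assay, with stated times of 2 h and 72 h, tested at 10 uM (a lower number here means a stronger inhibitor, a higher number a weaker inhibitor), compound 3 stands at 250 nM. Two steps place it: a 1.7-fold lower number from compound 2 to compound 3 (0.22 log units; within the scatter), and a 2.1-fold higher number from compound 1 to compound 3 (0.32 log units; beyond the scatter). It therefore cannot be separated from the azido analogue, while the propyl analogue holds the lower number.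

Compound 4 `COc1cccc(-n2nnc(-c3ccccc3NC(=O)Nc3ccc(N)cc3)n2)c1` changes the series at a new place: (4-aminophenyl)amino in place of 4-(((bromomethyl)carbonyl)amino)phenyl on a carbonyl carbon. Among the compounds with values here, no measured step alters this carbonyl link, so there is no direct precedent. The nearest guides are the replacements of propyl on an aromatic carbon, a 3.4-fold higher number from compound 1 to compound 2 (0.54 log units; beyond the scatter) and a 2.1-fold higher number from compound 1 to compound 3 (0.32 log units; beyond the scatter). Both were modest and both raised the number, and the exchange of one replacement for the other, a 1.7-fold lower number from compound 2 to compound 3 (0.22 log units; within the scatter), stayed small. A modest step is thus expected, tentatively towards a higher number, in this assay, estimated as a 2.2-fold higher number from compound 3 to compound 4 (0.34 log units; beyond the scatter). For compound 4 the expected value is 550 nM, with an estimated range of 170 nM to 1800 nM.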

Compound 4, half-maximal inhibitory concentration: 176 nM
The estimate for compound 4 lay 3.1-fold (0.49 log units) above the measured number, within the range that was stated.
By their numbers in this assay, from the lowest: compounds 1, 4, 3 and 2 (each within the scatter of the next, the first and the last beyond it).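

In this assay, within the data shown here, (4-aminophenyl)amino on the carbonyl carbon gives the first data on a change to this link, and the series tolerates it: a 1.4-fold lower number from compound 3 to compound 4 (0.15 log units; within the scatter) and a 1.5-fold higher number from compound 1 to compound 4 (0.16 log units; within the scatter) both stay within the scatter. Only a 2.4-fold lower number from compound 2 to compound 4 (0.37 log units; beyond the scatter) passes beyond the scatter, and that step is modest. The added amide-type nitrogen at this place therefore does not separate compound 4 from compound 1 or compound 3. No available evidence accounts for these steps.

Compound 4 changes the link and the group on the phenyl ring together, so the contribution of each remains unresolved. Also open, from the compounds shown here alone, is how a carboxylic acid or a chain longer than propyl on that phenyl ring would read with this link.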